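The source may report more compounds than this note shows. Statements on the series, on what has been measured and on what is new or still open speak of the compounds shown alone.

Within the data shown here, compound 1 `CCC(=O)N1CC2CC(C1)N2` gives 490 nM in an assay on SH-EP1 cells for agonist activity at Neuronal acetylcholine receptor; alpha4/beta2 (Homo sapiens), read by FLIPR and calcium flux (on this read-out lower numbers stand for an effect already at smaller amounts and higher numbers for an effect only at larger amounts of compound), and holds the lower of the two numbers known so far; compound 2 `O=C(C1CC=CC1)N1CC2CC(C1)N2` gives 6600 nM in this assay, a gap well beyond the usual scatter. Compound 3 `O=C([C@H]1C[C@H]1F)N1CC2CC(C1)N2` differs from compound 1 by 2-fluorocyclopropyl in place of ethyl on a carbonyl carbon. Among the measured compounds shown here, no measured pair shows this change directly. A modest rise is expected for the step of a 3.1-fold higher number from compound 1 to compound 3 (0.49 log units; beyond the scatter), beyond the scatter but far short of the gap to compound 2, because compound 2 in this assay gives 6600 nM with a much larger ring on the same carbonyl carbon. Compound 3 is therefore expected to give 1500 nM, within 500 nM to 5000 nM.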

Compound 3, half-maximal effective concentration: 210 nM
Estimate against measurement, compound 3: 7.1-fold (0.85 log units) above, outside the stated range (below it).
By their numbers in this assay, from the lowest: compound 3; then compound 1; then compound 2.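

On the carbonyl carbon of the shared core, 2-fluorocyclopropyl in place of ethyl brings a 2.3-fold lower number from compound 1 to compound 3 (0.37 log units; beyond the scatter) in this assay. This position therefore takes a larger group, with a three-membered ring and a fluorine, without any loss on this read-out. Nothing measured here explains the step. The compounds shown leave open whether the fluorine or the three-membered ring carries this step, and how plain cyclopropyl or a longer chain such as propyl would read at this place.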